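The source may hold more compounds than are shown below. What is called first, only, known or untested is meant among the compounds shown, and "the series" means these compounds.

Measured compounds:
Compound 1 `O=C1C(NC2CC2)=CC(=O)c2c1nc1n2[C@H]2OC[C@@H](O)[C@H]2OC1`: in a functional assay on HeLa cells (Homo sapiens) for inhibition, read by sulforhodamine B assay (on this read-out higher numbers stand for weaker inhibition and lower numbers for stronger inhibition), compound 1 gives > 16000 nM, which is a limit of the assay and not a number.
Compound 2 `O=C1C(N2CCCCC2)=CC(=O)c2c1nc1n2[C@H]2OC[C@@H](O)[C@H]2OC1`: compound 2 gives > 16000 nM, again a limit and not a number.
Compound 3 `CCOc1ccc(NC2=CC(=O)c3c(nc4n3[C@H]3OC[C@@H](O)[C@H]3OC4)C2=O)cc1`: compound 3 gives 14400 nM.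

Compound 3 is thus the only one of the three whose inhibition was pinned to a number; the other two values sit at the limit of > 16000 nM in this assay, at which 2 of the 3 values shown sit. Compound 4 `O=C1C(NC2CCCC2)=CC(=O)c2c1nc1n2[C@H]2OC[C@@H](O)[C@H]2OC1` has not yet been measured. It differs from compound 3 in one place: cyclopentyl in place of 4-ethoxyphenyl on an amine nitrogen.

For the measured compounds named here, one measured step bears on this change. The step of an at least 1.1-fold lower number from compound 1 to compound 3 (0.04 log units; that floor lies within the scatter) runs in the opposite sense, from a small carbon ring to 4-ethoxyphenyl, and its floor lies within the scatter, so it carries no readable direction. The step that the two limits leave unreadable from compound 1 to compound 2 cannot be read either. Swapping the 4-ethoxyphenyl back for a ring of carbon only therefore gives no reason to expect a shift beyond the scatter in this assay, though a value resting at the limit, as for compound 1, would not be surprising.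

Compound 4 is estimated at 20000 nM, with a range from 8000 nM to 50000 nM. The corresponding expected step is a 1.4-fold higher number from compound 3 to compound 4 (0.14 log units; within the scatter).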

Compound 4, half-maximal inhibitory concentration: > 16000 nM
Compound 4: no number, only a limit; the forecaster's own chance of this, stated with the estimate: 60%; the middle value is on the limit's open side.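

In this assay, compound 4, with cyclopentyl on the amine nitrogen, gives > 16000 nM, which is a limit of the assay and not a number. Putting cyclopentyl in place of 4-ethoxyphenyl is an at least 1.1-fold higher number from compound 3 to compound 4 (0.04 log units; that floor lies within the scatter), so even this direct comparison gives no readable direction for the change. The steps among compound 1, compound 2 and compound 4 cannot be read, but compound 4 adds a third compound with a non-aromatic carbon ring in this part of the molecule that stays at the limit, while compound 3, the one compound here with an aromatic ring at this place, is the exception with a number, and the data set now has this shape: the limit of > 16000 nM in this assay, at which 3 of the 4 values shown sit.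

Still open, on these data alone, is whether any group on this amine nitrogen can give a number clearly lower than that of compound 3, which a plain phenyl, a 4-methoxyphenyl or a 4-chlorophenyl group could begin to test. An open carbon chain such as n-butyl, or a chain ending in an amine or a carboxylic acid, would show whether a ring is needed here at all.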